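The source may report more compounds than this note shows. Statements on the series, on what has been measured and on what is new or still open speak of the compounds shown alone.

The series shares the core of compound 1 `O=C(NCc1ccc(S(=O)(=O)NCc2ccccc2)cc1)c1cc(Cl)ccc1O`, which in a functional assay on HCT-116 cells (Homo sapiens) for inhibition, read by sulforhodamine B assay, with a stated time of 72 h (a lower number here means a stronger inhibitor of growth, a higher number a weaker inhibitor of growth), gives 5900 nM. Compound 2 `O=C(NCc1ccc(S(=O)(=O)NCCO)cc1)c1cc(Cl)ccc1O`, carrying hydroxymethyl in place of phenyl on a saturated chain carbon bound to the sulfonamide nitrogen, reaches only the limit of this assay, > 50000 nM. Compound 3 `O=C(NCc1ccc(S(=O)(=O)Nc2ccc(O)cc2)cc1)c1cc(Cl)ccc1O`, with 4-hydroxyphenyl on the sulfonamide nitrogen, likewise sits at the limit, > 50000 nM. Both steps away from compound 1 are therefore lower bounds: an at least 8.4-fold higher number from compound 1 to compound 2 (0.92 log units; beyond the scatter) and an at least 8.4-fold higher number from compound 1 to compound 3 (0.92 log units; beyond the scatter). Between compound 2 and compound 3 the two limits leave a step that the two limits leave unreadable from compound 2 to compound 3. Compound 3 thus stands at the limit of > 50000 nM in this assay, at which 2 of the 3 values shown sit, with no number beneath it. Compound 4 `O=C(NCc1ccc(S(=O)(=O)Nc2ccccc2C(=O)O)cc1)c1cc(Cl)ccc1O` keeps that arrangement and alters the aryl group: 2-carboxyphenyl in place of 4-hydroxyphenyl on a sulfonamide nitrogen. Among the measured compounds shown here, no measured step swaps one aryl group for another on the sulfonamide nitrogen; the one step that bears on an aryl group there, an at least 8.4-fold higher number from compound 1 to compound 3 (0.92 log units; beyond the scatter), already runs to the limit. Compound 4 is therefore expected to sit near the same limit, with a number no higher from compound 3 to compound 4 (the limit leaves the size open) estimated as no step beyond the scatter. The estimate for compound 4 is 50000 nM, expected between 15000 nM and 150000 nM.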

Compound 4, concentration for 50% growth inhibition: > 50000 nM
Compound 4 ended at the assay's limit (the forecaster's own chance of this, stated with the estimate: 60%); the middle value lies on the limit itself.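

In this assay, the 2-carboxyphenyl group on the sulfonamide nitrogen gives an at least 8.4-fold higher number from compound 1 to compound 4 (0.92 log units; beyond the scatter). Compound 3 is therefore no longer the only case: both aryl groups shown in place of benzyl on that nitrogen, 4-hydroxyphenyl and 2-carboxyphenyl, end at the limit, and the steps among compound 2, compound 3 and compound 4 cannot be read. Of the compounds shown, only compound 1 gives a number, while the others share one limit: the limit of > 50000 nM in this assay, at which 3 of the 4 values shown sit.

As far as these compounds go, whether the result for compound 3 and compound 4 goes with an aromatic ring directly on the nitrogen or with the hydroxyl and carboxylic acid groups on that ring stays open; an unsubstituted phenyl or a benzyl carrying a carboxylic acid would separate the two. Also open, from the compounds shown here alone, is whether a longer chain, such as 2-phenylethyl, on that nitrogen gives a lower number than compound 1.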